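This account rests on a few compounds, and the source may have more. Where it says the series, first, only, none or still open, it means among the compounds named here.

Among the compounds with values here, only two compounds have been tested in an ADME assay on HEK293 cells (Homo sapiens) for cytotoxicity, read by luminescence, with a stated time of 72 h (on this read-out higher numbers stand for an effect only at larger amounts of compound and lower numbers for an effect already at smaller amounts), compound 1 (`CCOC(=O)c1c(-c2cccc(Oc3ccccc3)c2)[nH]c2cc(OC)ccc2c1=O`) and compound 2 (`CCOC(=O)c1c(-c2cccc(-c3ccccc3)c2)[nH]c2cc(O)ccc2c1=O`). Compound 1 gives > 22000 nM, which is a limit of the assay and not a number. Compound 2 gives > 22000 nM, which is also a limit, so its standing rests on (the limit of > 22000 nM in this assay, at which 2 of the 2 values shown sit). Compound 3 (`CCOC(=O)c1c(-c2cccc(Oc3ccccc3)c2)[nH]c2cc(O)ccc2c1=O`) differs from compound 2 by phenoxy in place of phenyl on an aromatic carbon, meta to a large group: phenoxy in place of phenyl on an aromatic carbon. No measured step sizes this change in this assay. Compound 3 shares the phenoxy group with compound 1, which gives > 22000 nM, a limit. The expected change is none beyond the scatter, with an estimated a number no higher from compound 2 to compound 3 (the limit leaves the size open). For compound 3 the estimated value is 22000 nM, with an expected range from 9000 nM to 30000 nM.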

Compound 3, half-maximal effective concentration: > 22000 nM
Compound 3: only a limit was reported (the forecaster's own chance of this, stated with the estimate: 85%); the middle value sits exactly at the limit.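

No new step can be read in this assay between compound 3 and either compound 2 or compound 1, because all of these values are limits of the assay and not numbers: the limit of > 22000 nM in this assay, at which 3 of the 3 values shown sit.

The compounds shown leave open whether swapping phenoxy for phenyl, or hydrogen for methyl on the oxygen, changes this read-out at all.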